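The source may hold more compounds than are shown below. What is called first, only, known or untested is meant among the compounds shown, and "the series" means these compounds.

Compound 1 `COc1ccc([C@H]2CC(=O)N(c3cccc(O)c3)C2)cc1OC1CCCC1`: in a functional assay on HEK293 cells (Homo sapiens) for cytotoxicity (on this read-out higher numbers stand for lower toxicity in this test and lower numbers for higher toxicity in this test), compound 1 reaches only the limit of the assay, > 10000 nM.
Compound 2 `COc1ccc([C@H]2CC(=O)N(c3cccc(C(F)(F)F)c3)C2)cc1OC1CCCC1`: compound 2 likewise gives only the limit > 10000 nM.
Compound 3 `COc1ccc([C@H]2CC(=O)N(c3cccc(NCCCc4ccccc4)c3)C2)cc1OC1CCCC1`: compound 3 also stops at the limit > 10000 nM.

All three values sit at the same limit (the limit of > 10000 nM in this assay, at which 3 of the 3 values shown sit), so the steps a step that the two limits leave unreadable from compound 1 to compound 2, a step that the two limits leave unreadable from compound 1 to compound 3 and a step that the two limits leave unreadable from compound 2 to compound 3 have no readable size and compound 3 stands at the limit with the others. Compound 4 `COc1ccc([C@H]2CC(=O)N(c3cccc(NS(=O)(=O)c4cccc(Cl)c4C)c3)C2)cc1OC1CCCC1` differs from compound 3 by (3-chloro-2-methylphenyl)sulfonyl in place of 3-phenylpropyl on a nitrogen on an aromatic ring. Every measured step ended at the limit (the limit of > 10000 nM in this assay, at which 3 of the 3 values shown sit), so none of them bears readably on this change, and no shift beyond the scatter can be argued for in either direction. Compound 4 is therefore expected to remain at the limit as well, with an estimate of 10000 nM, ranging from 5000 nM to 30000 nM. The expected step is a number no higher from compound 3 to compound 4 (the limit leaves the size open).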

Compound 4, half-maximal cytotoxic concentration: > 10000 nM
Compound 4: a limit, no number (the forecaster's own chance of this, stated with the estimate: 80%); the middle value sits exactly at the limit.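

Compound 4 also stops at a limit, so no step among compound 1, compound 2, compound 3 and compound 4 can be read: the limit of > 10000 nM in this assay, at which 4 of the 4 values shown sit.

The compounds shown leave open how far they truly differ in this assay, and whether any change to this group would give a measurable value.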